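The compounds below may be only part of what the source reports. "The series", "measured", "known", "first", "only" and "open" are said of these compounds alone.

Two compounds of the series carry numbers. Compound 1 `COc1cc(CC2C(C#N)=C(N)N(c3ccc(S(N)(=O)=O)cc3)C3=C2C(=O)CCC3)ccc1O` gives 90% in a functional assay on Ehrlich cells (Mus musculus) for antiproliferative activity, read by trypan blue exclusion, with a stated time of 2 h, tested at 50 ug/mL; on this read-out lower numbers stand for a weaker effect and higher numbers for a stronger effect at the one concentration tested. Compound 2 `N#CC1=C(N)N(c2ccc(S(N)(=O)=O)cc2)C2=C(C(=O)CCC2)C1c1ccc([N+](=O)[O-])cc1` gives 95% in this assay. Compound 2 sits at the top of the two numbers shown, but its only neighbour is compound 1, and the step of a number 5 percentage points higher from compound 1 to compound 2 (within the scatter) does not separate them. Compound 3 `N#CC1=C(N)N(c2ccc(S(N)(=O)=O)cc2)C2=C(C(=O)CCC2)C1c1ccc(Cl)cc1Cl` is not yet measured. It differs from compound 2 in one place: 2,4-dichlorophenyl in place of 4-nitrophenyl on a saturated ring carbon. For the measured compounds named here, the one measured step at this saturated ring carbon, a number 5 percentage points higher from compound 1 to compound 2 (within the scatter), exchanged a different pair of groups and stayed within the scatter; no step involving 2,4-dichlorophenyl is known. The change is therefore expected to move the number little, a step of a number 3 percentage points lower from compound 2 to compound 3 (within the scatter). Compound 3 is estimated at 92%, with a range from 78% to 100%.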

Compound 3, a percentage reported as activity, at one concentration (the size of the read-out at that concentration, not a potency): 65%
For compound 3 the middle estimate is 27 percentage points above the measured one, and the stated range ends above it.
By their numbers in this assay, from the lowest: compound 3; then compounds 1 and 2 (each within the scatter of the next).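

At this saturated ring carbon, 2,4-dichlorophenyl in place of 4-nitrophenyl gives in this assay a number 30 percentage points lower from compound 2 to compound 3 (beyond the scatter) and 2,4-dichlorophenyl in place of 4-hydroxy-3-methoxybenzyl gives a number 25 percentage points lower from compound 1 to compound 3 (beyond the scatter) in the same read-out. The earlier pair offered only a step within the scatter, so the position now proves responsive to the group it carries, although 4-nitrophenyl and 4-hydroxy-3-methoxybenzyl cannot be told apart. Nothing on hand bears on what lies behind this loss of effect.

On these data alone, whether the lower number follows the chlorine atoms or the 2,4-dichlorophenyl group as a whole stays open, and a plain phenyl, a phenyl with a single chlorine or an aminophenyl group at this carbon would bear on that. With a single concentration per compound, these numbers also give no potency for any of the three.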